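Triazole nitrogen substituent removed from long-chain amide analogue

This account rests on a few compounds, and the source may have more. Where it says the series, first, only, none or still open, it means among the compounds named here.

Measured compounds in an assay on 32D cells for inhibition of interleukin-15 (Mus musculus), read by resazurin assay, with stated times of 30 min and 2.5 days, in the presence of a further agent that is not named here; a higher number here means a weaker inhibitor, a lower number a stronger inhibitor:
- compound 1, `Cn1c(Cc2nn(C)c(=O)c3ccccc23)nnc1SCC(=O)Nc1ccc(Cl)cc1Cl`, 22500 nM
- compound 2, `CCOC(CCn1c(Cc2nn(C)c(=O)c3ccccc23)nnc1SCCCCCCCC(=O)Nc1ccc(Cl)cc1Cl)OCC`, 12100 nM
- compound 3, `Cn1nc(Cc2nnc(SCC(=O)Nc3ccc(Cl)cc3Cl)n2CCC=O)c2ccccc2c1=O`, 6000 nM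

Compound 2 gives the second highest of the three numbers in this assay; its gap to compound 1 is within the scatter, as is its gap to compound 3. Compound 4, `Cn1nc(Cc2nnc(SCCCCCCCC(=O)Nc3ccc(Cl)cc3Cl)[nH]2)c2ccccc2c1=O`, differs from compound 2 by hydrogen in place of 3,3-diethoxypropyl on an aromatic nitrogen. Among the compounds with values here, no measured step removes this group; the only related step is a 3.8-fold lower number from compound 1 to compound 3 (0.57 log units; beyond the scatter), a modest change for a chain grown on that nitrogen, so removal of the chain may go the other way. Compound 4 is therefore expected to give 18000 nM (range 7000 nM to 45000 nM), which means an expected step of a 1.5-fold higher number from compound 2 to compound 4 (0.17 log units; within the scatter), likely within the scatter.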

Compound 4, half-maximal inhibitory concentration: 1100 nM
Compound 4: middle estimate off by 16-fold (1.21 log units), on the high side, outside the stated range (below it).
By their numbers in this assay, from the lowest: compound 4; then compounds 3, 2 and 1 (each within the scatter of the next, the first and the last beyond it).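

In this assay, hydrogen in place of 3,3-diethoxypropyl on the aromatic nitrogen gives an 11-fold lower number from compound 2 to compound 4 (1.04 log units; beyond the scatter), so this position need not carry a chain in the long-chain amide. Changes at this nitrogen follow no single direction, since growing the group with formylmethyl also gives a lower number, a 3.8-fold lower number from compound 1 to compound 3 (0.57 log units; beyond the scatter), in the short-chain amide. No supporting evidence explains either step.

As far as these compounds go, it remains open whether hydrogen at this nitrogen has a similar effect in the short-chain amide of compound 1. How an amine or a carboxylic acid on a chain at this nitrogen would read is also unresolved.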